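Pyrimidin-2-yl in place of pyridin-4-yl on the cyclopropane

The source may hold more compounds than are shown below. What is called first, only, known or untested is meant among the compounds shown, and "the series" means these compounds.

Of the compounds shown here, two have been measured in a functional assay for agonist activity at G protein-coupled receptor 88 (Homo sapiens), read by HTRF and cAMP accumulation; on this read-out lower numbers stand for an effect already at smaller amounts and higher numbers for an effect only at larger amounts of compound. Compound 1 `CC[C@H](C)[C@H](N)CN(C(=O)[C@@H]1C[C@H]1C1CCCCC1)c1ccc(-c2ccccc2)cc1` reaches only the limit of the assay, giving > 25000 nM. Among the compounds with values here, compound 2 `CC[C@H](C)[C@H](N)CN(C(=O)[C@@H]1C[C@H]1c1ccncc1)c1ccc(-c2ccccc2)cc1` gives 1500 nM in this assay, the only number among the values shown, the other being (the limit of > 25000 nM in this assay, at which 1 of the 2 values shown sits). The measured step of an at least 16-fold lower number from compound 1 to compound 2 (1.22 log units; beyond the scatter) is therefore large. Compound 3 `CC[C@H](C)[C@H](N)CN(C(=O)[C@@H]1C[C@H]1c1ncccn1)c1ccc(-c2ccccc2)cc1` carries the change (pyrimidin-2-yl in place of pyridin-4-yl on a saturated ring carbon). Within the data shown here, the one measured step bears on it only loosely: it shows that an aromatic ring with a nitrogen outperforms the saturated cyclohexyl, but it says nothing about moving the ring nitrogen or adding a second one. The expectation for compound 3 is therefore a number near that of compound 2, with wide uncertainty, as the step of a 2.0-fold higher number from compound 2 to compound 3 (0.30 log units; within the scatter). Compound 3 is estimated to give 3000 nM in this assay, between 800 nM and 12000 nM.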

Compound 3, half-maximal effective concentration: 130 nM
The estimate for compound 3 lay 23-fold (1.36 log units) above the measured number, outside the stated range (below it).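

With two aromatic rings of the same size on this saturated ring carbon of the cyclopropane, this assay now tells them apart, not only an aromatic ring from cyclohexyl: pyrimidin-2-yl in place of pyridin-4-yl gives a 12-fold lower number from compound 2 to compound 3 (1.06 log units; beyond the scatter). Set against cyclohexyl at the same place, pyrimidin-2-yl gives an at least 190-fold lower number from compound 1 to compound 3 (2.28 log units; beyond the scatter). The value of compound 1 in that step is a limit of the assay and not a number: the limit of > 25000 nM in this assay, at which 1 of the 3 values shown sits.

Still open, from the compounds shown here alone, is whether the step follows the second ring nitrogen or the place of the nitrogens, a question that pyridin-2-yl or pyrimidin-5-yl on this carbon would bear on. Also open, going by these compounds, is how the position responds to an amine or a methyl group on the pyrimidin-2-yl ring.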